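Inverting One Stereocentre: Compound 2 to Compound 4

This account rests on a few compounds, and the source may have more. Where it says the series, first, only, none or still open, it means among the compounds named here.

Measured so far:
compound 1 `CC[C@H](C)[C@@H]1C(=O)N[C@H](C2Cc3ccccc3C2)C(=O)N1[C@@H](C(=O)N(C)C)c1cc(C)cnc1C`: 13 mL.min-1.g-1
compound 2 `CC[C@H](C)[C@@H]1C(=O)N[C@H](C2Cc3ccccc3C2)C(=O)N1[C@@H](C(=O)N1CCOCC1)c1ccc(C)nc1`: 6 mL.min-1.g-1
compound 3 `CCC(CC)[C@@H]1C(=O)N[C@H](C2Cc3ccccc3C2)C(=O)N1[C@@H](C(=O)N1CCOCC1)c1ccc(C)nc1C`: 14 mL.min-1.g-1

In an in vitro ADME assay on microsomes from liver (Macaca fascicularis) for metabolic stability (on this read-out lower numbers stand for slow clearance and higher numbers for fast clearance), compound 2 gives the lowest of the three numbers; compound 1 and compound 3 both lie beyond the scatter above it. Compound 4 `CC[C@@H](C)[C@@H]1C(=O)N[C@H](C2Cc3ccccc3C2)C(=O)N1[C@@H](C(=O)N1CCOCC1)c1ccc(C)nc1` has the same atoms and bonds as compound 2 and differs only in configuration as drawn: the two compounds have the same atoms and bonds and differ only in configuration as drawn: 1 of 4 stereo elements differ; a stereocentre at a saturated chain carbon is drawn S in compound 2 and R in compound 4. For the measured compounds named here, no measured pair shows what such an inversion does in this assay, so the expectation rests on compound 2 alone. The expected step of a 1.3-fold higher number from compound 2 to compound 4 (0.12 log units; within the scatter) is small, likely within the scatter, and could fall in either direction. Compound 4 is therefore estimated at 8 mL.min-1.g-1, with a range from 4 mL.min-1.g-1 to 18 mL.min-1.g-1.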

Compound 4, intrinsic clearance in microsomes: 8 mL.min-1.g-1
Compound 4: middle estimate and measured number agree at the digits printed, and the stated range covers the measured number.
By their numbers in this assay, from the lowest: compounds 2, 4, 1 and 3 (each within the scatter of the next, the first and the last beyond it).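

In this assay, for the compounds shown here, the pair gives the first step between compounds that differ in one place: a 1.3-fold higher number from compound 2 to compound 4 (0.12 log units; within the scatter). Going by these compounds alone, at this saturated chain carbon, then, going from S to R leaves the number within the scatter, which the earlier compounds, differing in several places, could not show. The step reads as one of configuration alone: the fact that compounds 2 and 4 differ only in the configuration as drawn

The compounds shown leave open whether the same inversion stays this small on the core of compound 1. They also leave open what a longer chain or a cyclohexyl group at this position would give in this assay.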